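The compounds below may be only part of what the source reports. "The series", "measured", "known", "first", "only" and "open" are said of these compounds alone.

Compound 3 `COc1cc(C(=O)N2CCC(CCN3CCC(C(=O)c4nc5ccccc5n4CCOc4ccco4)CC3)(c3ccccc3)C2)cc(OC)c1OC` is the reference for this step. In a functional assay for antagonist activity at Substance-P receptor (Cavia porcellus) (a higher number here means a weaker inhibitor, a lower number a stronger inhibitor), compound 3 gives 12 nM, the lowest number among the three measured compounds. The gap to compound 1 `COc1cc(C(=O)N2CCC(CCN3CCC(C(=O)c4nc5ccccc5n4Cc4ccco4)CC3)(c3ccccc3)C2)cc(OC)c1OC`, which in this assay gives 21 nM, is within the scatter: a 1.8-fold lower number from compound 1 to compound 3 (0.24 log units; within the scatter). The gap to compound 2 `CCOCCn1c(C(=O)C2CCN(CCC3(c4ccccc4)CCN(C(=O)c4cc(OC)c(OC)c(OC)c4)C3)CC2)nc2ccccc21`, which gives 26 nM, is beyond it but modest: a 2.2-fold lower number from compound 2 to compound 3 (0.34 log units; beyond the scatter). Between the other two, a 1.2-fold higher number from compound 1 to compound 2 (0.09 log units; within the scatter).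

Compound 4 `COc1cc(C(=O)N2CCC(CCN3CCC(C(=O)c4nc5ccccc5[nH]4)CC3)(c3ccccc3)C2)cc(OC)c1OC` differs from compound 3 in one place: hydrogen in place of 2-((furan-2-yl)oxy)ethyl on an aromatic nitrogen. All three measured steps touch the same aromatic nitrogen, but each exchanges one substituent for another and none removes the substituent altogether. Among the measured compounds shown here, those exchanges moved the number little, at most modestly, which suggests this position tolerates variation, yet the bare ring nitrogen of compound 4 has no direct precedent here, so the step is less well constrained than the measured ones. For the measured compounds named here, on that basis a somewhat higher number is expected for compound 4, with a wider band of uncertainty than the earlier steps would suggest: a 3.8-fold higher number from compound 3 to compound 4 (0.57 log units; beyond the scatter). The estimate for compound 4 in this assay is 45 nM, with a range from 12 nM to 180 nM.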

Compound 4, half-maximal inhibitory concentration: 36 nM
Compound 4: middle estimate off by 1.3-fold (0.10 log units), on the high side; the range from low to high includes it.
By their numbers in this assay, from the lowest: compounds 3, 1, 2 and 4 (each within the scatter of the next, the first and the last beyond it).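

Among the compounds shown here, removing the whole substituent from the aromatic nitrogen gives the first direct reading of the bare ring nitrogen in this assay: there is a 3.0-fold higher number from compound 3 to compound 4 (0.48 log units; beyond the scatter), so the 2-((furan-2-yl)oxy)ethyl group of compound 3 is separated from hydrogen by a modest step, and activity in this assay does not depend on a substituent at this place. The other two substituents are not separated from hydrogen: there is a 1.4-fold higher number from compound 2 to compound 4 (0.14 log units; within the scatter) and a 1.7-fold higher number from compound 1 to compound 4 (0.23 log units; within the scatter), so among the groups shown, only 2-((furan-2-yl)oxy)ethyl stands apart from the bare nitrogen, and neither 2-ethoxyethyl nor (furan-2-yl)methyl shows a measurable gain over it. No supporting measurement is available to account for this difference among the substituents.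

From the compounds shown here alone, it remains open whether a methyl group, a 2-aminoethyl chain, a carboxymethyl group or a longer chain such as 4-((furan-2-yl)oxy)butyl on this nitrogen would read with compound 3 or with compound 4. Also open, going by these compounds, is whether the same modest step from the 2-((furan-2-yl)oxy)ethyl group to hydrogen would hold on a core changed elsewhere, as all four compounds share one core.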